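A few compounds are considered here, and "the series" means these few. Any claim that something is new, unique, unknown or untested is made for them only; others in the source may bear on it.

Measured in a functional assay on LNCaP cells (Homo sapiens) for cytotoxicity, read by sulforhodamine B assay, with a stated time of 72 h; on this read-out lower numbers stand for stronger inhibition and higher numbers for weaker inhibition:
- Compound 1 `COc1cc(/C=C/C(O)=C/C(=O)/C=C/c2ccc(OC)c(OC)c2)ccc1O`: 47000 nM
- Compound 2 `COc1cc(/C=C/C(=O)/C=C(O)/C=C/c2ccc(OC(C)(C)C(=O)Nc3ccc([N+](=O)[O-])c(C(F)(F)F)c3)c(OC)c2)ccc1O`: > 100000 nM, a limit of the assay and not a number
- Compound 3 `COc1cc(/C=C/C(=O)/C=C(O)/C=C/c2ccc(OC(C)(C)C(=O)Nc3ccc(F)c(C(F)(F)F)c3)c(OC)c2)ccc1O`: 54800 nM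

Compound 3 at 54800 nM and compound 1 at 47000 nM lie within the scatter of each other. Within the data shown here, these are the only two numbers.

Compound 4 `COc1cc(/C=C/C(=O)/C=C(O)/C=C/c2ccc(OC(C)(C)C(=O)Nc3ccc(C)c(C(F)(F)F)c3)c(OC)c2)ccc1O` carries methyl in place of fluoro on an aromatic carbon, ortho to a trifluoromethyl group and para to a large group: methyl in place of fluoro on an aromatic carbon.

Among the measured compounds shown here, one measured step bears on this place: an at least 1.8-fold lower number from compound 2 to compound 3 (0.26 log units; that floor lies within the scatter), with fluoro in place of nitro. Its floor lies within the scatter, so it gives no firm size. No step beyond the scatter is expected in this assay. The estimated step is a 1.1-fold higher number from compound 3 to compound 4 (0.02 log units; within the scatter). For compound 4 the expected value is 58000 nM, with an estimated range of 28000 nM to 100000 nM.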

Compound 4, half-maximal inhibitory concentration: > 100000 nM
Compound 4: only a limit was reported; the forecaster's own chance of this, stated with the estimate: 20%; middle value at least 1.7-fold (0.23 log units) away from the limit.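

Methyl in place of fluoro on this aromatic carbon gives an at least 1.8-fold higher number from compound 3 to compound 4 (0.26 log units; that floor lies within the scatter), so the change has a floor but no firm size. Of nitro, fluoro and methyl at this place, only fluoro returns a number, and the values of compound 2 and compound 4 are limits of the assay and not numbers: the limit of > 100000 nM in this assay, at which 2 of the 4 values shown sit.
The step between compound 2 and compound 4 cannot be read.

From the compounds shown here alone, the true size of the step to compound 4 stays open. So does whether chloro or an amine on this carbon would return a number.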